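A few compounds are considered here, and "the series" means these few. Any claim that something is new, unique, unknown or untested is made for them only; others in the source may bear on it.

In a functional assay on U-87MG ATCC cells (Homo sapiens) for cytotoxicity, read by MTT assay, with a stated time of 72 h (on this read-out lower numbers stand for stronger inhibition and higher numbers for weaker inhibition), three compounds built on one shared core have been measured. Compound 1 `CN(C)CCn1cnnc1-c1cc(Oc2ccc(NC(=O)N/N=C/c3cc(C(C)(C)C)cc(C(C)(C)C)c3O)cc2F)ccn1` gives 520 nM, compound 2 `CN(C)CCn1cnnc1-c1cc(Oc2ccc(NC(=O)N/N=C/c3c(O)ccc4ccccc34)cc2F)ccn1` gives 620 nM, and compound 3 `CN(C)CCn1cnnc1-c1cc(Oc2ccc(NC(=O)N/N=C/c3ccccc3O[N+](=O)[O-])cc2F)ccn1` gives 7150 nM. Compound 3 therefore stands highest of the three numbers, with compound 2 its nearest neighbour and compound 1 its furthest. Compound 1 and compound 2 both carry an aryl group bearing a hydroxyl on the carbon with a double bond to nitrogen, whereas compound 3 carries 2-(nitrooxy)phenyl there; the single one-place step among these data, a 12-fold higher number from compound 2 to compound 3 (1.06 log units; beyond the scatter), shows that the identity of this aryl group weighs heavily on the read-out.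

Compound 4 `CN(C)CCn1cnnc1-c1cc(Oc2ccc(NC(=O)N/N=C/c3ccccc3)cc2F)ccn1` is the next compound and differs from compound 3 in one place: hydrogen in place of nitrooxy on an aromatic carbon. Going by the values given here, no measured step removes a nitrooxy group on its own, so the only guide is that exchanging this aryl group has once shifted the number by a large amount, and compound 4 bears neither a hydroxyl nor a nitrooxy group, resembling neither side of that step. A modest step is therefore expected, a 2.0-fold lower number from compound 3 to compound 4 (0.31 log units; beyond the scatter), most likely toward a lower number but with wide uncertainty. Compound 4 is estimated at 3500 nM, within a range from 900 nM to 14000 nM.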

Compound 4, half-maximal inhibitory concentration: 2250 nM
Compound 4: the middle estimate sits 1.6-fold (0.19 log units) above what was measured; measured number inside the range.
By their numbers in this assay, from the lowest: compounds 1 and 2 (each within the scatter of the next); then compound 4; then compound 3.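

In this assay, taking the nitrooxy group off the ring and leaving plain phenyl gives a 3.2-fold lower number from compound 3 to compound 4 (0.50 log units; beyond the scatter), so on this scaffold the nitrooxy group goes with weaker inhibition than hydrogen on the same aromatic carbon. Plain phenyl still does not match the hydroxyl-bearing 2-hydroxynaphthalen-1-yl group, with a 3.6-fold higher number from compound 2 to compound 4 (0.56 log units; beyond the scatter), which places compound 4 in the middle and splits the large gap between compound 2 and compound 3 into two modest steps, each beyond the usual scatter. Nothing measured here explains either step.

The step from compound 2 to compound 4 changes the size of the aryl group and removes the hydroxyl together, so these data cannot say which of the two matters more, and a 2-hydroxyphenyl group would be the natural way to separate them. As far as these compounds go, it also remains open how an amine or a carboxylic acid on the aromatic carbon that carries nitrooxy in compound 3 would compare with the hydrogen of compound 4.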